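This account rests on a few compounds, and the source may have more. Where it says the series, first, only, none or still open, it means among the compounds named here.

Compound 1 `O=C1C=C(NCc2ccccc2)C(=O)c2c1nc1n2[C@H]2OC[C@@H](O)[C@H]2OC1`: in a functional assay on HeLa cells (Homo sapiens) for inhibition, read by sulforhodamine B assay (on this read-out higher numbers stand for weaker inhibition and lower numbers for stronger inhibition), compound 1 gives > 8000 nM, which is a limit of the assay and not a number.
Compound 2 `COc1ccc(NC2=CC(=O)c3nc4n(c3C2=O)[C@H]2OC[C@@H](O)[C@H]2OC4)cc1`: in this assay compound 2 gives 4780 nM.

For the measured compounds named here, compound 2 therefore carries the only numerical value shown; the other value is a limit. Its structure differs from compound 1 in one place, 4-methoxyphenyl in place of benzyl on an amine nitrogen, and that change gave an at least 1.6-fold lower number from compound 1 to compound 2 (0.22 log units; that floor lies within the scatter). As far as these compounds go, because one of the two values sits at the limit of > 8000 nM in this assay, at which 1 of the 2 values shown sits, the true size of that step stays open.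

Compound 3 `O=C1C=C(N2CCCC2)C(=O)c2c1nc1n2[C@H]2OC[C@@H](O)[C@H]2OC1` has not yet been measured. It differs from compound 2 by pyrrolidin-1-yl in place of (4-methoxyphenyl)amino on a double-bonded ring carbon. The step from compound 1 to compound 2 is the only measured one and also alters the group attached there, but it swaps one nitrogen-bound group for another while keeping the amine hydrogen; here that hydrogen is lost. Going by the values given here, no measured step covers such a change, so no direction can be drawn from the data. Compound 3 is expected to land near compound 2, with a real chance that it falls back to a limit. The expected step is a 1.5-fold higher number from compound 2 to compound 3 (0.17 log units; within the scatter). The estimate for compound 3 is 7000 nM, with a range from 2500 nM to 20000 nM.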

Compound 3, half-maximal inhibitory concentration: > 16000 nM
Compound 3 was reported as a limit; the forecaster's own chance of this, stated with the estimate: 45%; middle value at least 2.2-fold (0.35 log units) away from the limit.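

Putting pyrrolidin-1-yl in place of (4-methoxyphenyl)amino on the double-bonded ring carbon gives an at least 3.3-fold higher number from compound 2 to compound 3 (0.52 log units; beyond the scatter). Among the compounds shown, this is the only step at this position that is known to exceed the scatter, so it gives the first firm sign that the group attached here matters in this assay, where a higher number means weaker inhibition. Compound 1 and compound 3 both stand at limits of the assay, so the step between them cannot be read.

This single change removes the aromatic ring and the amine hydrogen together, so the compounds shown do not separate the two: a cyclopentylamino group would keep the hydrogen without the aromatic ring, while an N-methyl-(4-methoxyphenyl)amino group would keep the ring without the hydrogen. As far as these compounds go, whether the methoxy group on the aromatic ring contributes also stays open, and a plain phenylamino group at the same carbon would test this directly against compound 2.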